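A few compounds are considered here, and "the series" means these few. Any claim that something is new, unique, unknown or untested is made for them only; others in the source may bear on it.

Measured in a functional assay on A549 cells (Homo sapiens) for antiproliferative activity, read by MTT assay, with a stated time of 48 h; on this read-out higher numbers stand for weaker inhibition and lower numbers for stronger inhibition:
Compound 1 `COc1cc(-c2nnc3c(OC)cc(-c4ccc5[nH]cc(C=O)c5c4)cn23)cc(OC)c1OC`: > 10000 nM
Compound 2 `CCOc1cc(-c2ccc3c(ccn3C)c2)cn2c(-c3cc(OC)c(OC)c(OC)c3)nnc12`: 334 nM
Compound 3 `COc1cc(-c2nnc3c(OC)cc(-c4ccc5c(ccn5C)c4)cn23)cc(OC)c1OC`: 69 nM

The entry for compound 1, > 10000 nM, is a limit and not a number. Of the two true numbers in this assay, the lower belongs to compound 3, at 69 nM. Compound 4 `COc1cc(-c2nnc3c(OC4COC4)cc(-c4ccc5c(ccn5C)c4)cn23)cc(OC)c1OC` carries oxetan-3-yl in place of methyl on an oxygen on an aromatic ring. The closest evidence is a 4.8-fold lower number from compound 2 to compound 3 (0.68 log units; beyond the scatter), which concerns the group on this same oxygen. Read in reverse, the longer chain gave the higher number. The large at least 140-fold lower number from compound 1 to compound 3 (2.16 log units; beyond the scatter) lies elsewhere in the molecule and does not bear on this change. A modest move in the same direction is therefore expected, a 5.8-fold higher number from compound 3 to compound 4 (0.76 log units; beyond the scatter). The estimate for compound 4 is 400 nM, with an expected range of 120 nM to 2000 nM.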

Compound 4, half-maximal inhibitory concentration: 516 nM
Estimate against measurement, compound 4: 1.3-fold (0.11 log units) below, and the stated range covers the measured number.
By their numbers in this assay, from the lowest: compound 3; then compounds 2 and 4 (each within the scatter of the next). At a limit, above all of these: compound 1.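

Replacing methoxy with (oxetan-3-yl)oxy raises the number (a 7.5-fold higher number from compound 3 to compound 4 (0.87 log units; beyond the scatter)), so this ring on the oxygen does not keep the level reached with methyl. The oxetan-3-yl and ethyl groups cannot be told apart here (a 1.5-fold higher number from compound 2 to compound 4 (0.19 log units; within the scatter)), which leaves methyl with the lowest number of the three groups shown on this oxygen. Nothing shown accounts for this difference. The compounds shown leave open how a hydroxyl in place of the methoxy, or a chain ending in an amine on this oxygen, would compare.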